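The source may hold more compounds than are shown below. What is called first, only, known or untested is meant among the compounds shown, and "the series" means these compounds.

Working notes on the thiadiazole thioglycoside amides.

For the measured compounds named here, compound 1 `CCCCCCCCCCCCCCCCCC(=O)Nc1nnc(S[C@@H]2O[C@H](COC(C)=O)[C@H](OC(C)=O)[C@H](OC(C)=O)[C@H]2OC(C)=O)s1` is the only member of the set with a numerical result: in a functional assay on DU-145 cells (Homo sapiens) for cytotoxicity, read by MTT assay, with a stated time of 24 h (on this read-out lower numbers stand for stronger inhibition and higher numbers for weaker inhibition), compound 1 gives 31200 nM. Compound 2 `CCCCCCCCCCCCCCCC(=O)Nc1nnc(S[C@@H]2O[C@H](CO)[C@H](O)[C@H](O)[C@H]2O)s1`, which carries a somewhat shorter saturated amide chain and free hydroxyls in place of the acetates, is reported in this assay as "not active" (no number reported), with no number attached. Compound 3 `CCCCCCCC/C=C\CCCCCCCC(=O)Nc1nnc(S[C@@H]2O[C@H](CO)[C@H](O)[C@H](O)[C@H]2O)s1`, the corresponding unsaturated amide with free hydroxyls, is likewise reported in this assay as "not active" (no number reported). Compound 1 thus stands alone on the numbers shown; the two other entries give nothing to rank against it, and no step between measured compounds can be counted.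

Compound 4 `C=CCCCCCCCCC(=O)Nc1nnc(S[C@@H]2O[C@H](COC(C)=O)[C@H](OC(C)=O)[C@H](OC(C)=O)[C@H]2OC(C)=O)s1` keeps the acetylated sugar and the amide of compound 1 but has a much shorter chain: vinyl in place of nonyl on a saturated chain carbon, eight bonds along the chain from a carbonyl carbon. Going by the values given here, no measured pair shows what chain length does on the acetylated core, so the direction of the step is open. The two hydroxyl compounds, compound 2 and compound 3, say only that long chains without acetates gave no number. With compound 1 already weak, the expectation for compound 4 is a step of a 1.4-fold higher number from compound 1 to compound 4 (0.16 log units; within the scatter), within or just beyond the scatter, toward slightly weaker inhibition. Compound 4 is therefore estimated at 45000 nM, with a range from 15000 nM to 150000 nM.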

Compound 4, half-maximal inhibitory concentration: 22900 nM
For compound 4 the middle estimate is 2.0-fold (0.29 log units) above the measured one, within the range that was stated.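

Read in this assay, vinyl in place of nonyl on a saturated chain carbon, eight bonds along the chain from a carbonyl carbon, gives a 1.4-fold lower number from compound 1 to compound 4 (0.13 log units; within the scatter) and is the first step that can be counted in the series. On the acetylated core, the full nonyl stretch of the chain is therefore not needed to keep a measurable number in this pair, and the shortened chain ending in a double bond cannot be told apart from the longer saturated one. No measurement at hand offers an explanation for this result.

It remains open whether chain length and the terminal double bond each leave the number unchanged or whether their contributions offset each other: the compounds shown include no saturated chain matching the length of the one in compound 4, no longer chain on the acetylated core, and no chain ending in an amine or a carboxylic acid. As far as these compounds go, the role of the acetates also remains open, as compound 2 and compound 3 differ from the acetylated compounds in more than one place and their entries carry no number.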